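Swapping the pyridine on the core of compound 1

This account rests on a few compounds, and the source may have more. Where it says the series, first, only, none or still open, it means among the compounds named here.

Measured so far:
compound 1, `Cc1oc(C(=O)O)cc1COc1ccc(-c2ccncc2)cc1`, > 10000 nM
compound 2, `Cc1oc(CC(=O)O)cc1COc1ccc(-c2ccccc2)cc1`, 80 nM
compound 3, `CC(=O)c1ccc(-c2ccc(OCc3cc(C(=O)NS(=O)(=O)c4ccccc4)oc3C)cc2)cc1`, 20 nM

Of the compounds shown here, three sharing one core have been tested in an assay on cells for displacement of a labelled ligand from prostaglandin E2 receptor EP4 subtype (Homo sapiens), read by scintillation counting; a higher number here means a weaker inhibitor, a lower number a stronger inhibitor. In this assay compound 1 gives only a limit, > 10000 nM, so no number is known for it. Compound 2 gives 80 nM, and compound 3 gives 20 nM. Compound 1 is therefore the one of the three that sits at the limit of > 10000 nM in this assay, at which 1 of the 3 values shown sits, with the other two far from it.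

The untested compound 4, `COc1ccc(-c2ccc(OCc3cc(C(=O)O)oc3C)cc2)nc1`, differs from compound 1 in a single place: 5-methoxypyridin-2-yl in place of pyridin-4-yl on an aromatic carbon. Within the data shown here, no measured pair shows this same change, so its effect can only be guessed. From compound 1 to compound 4 a gain in binding is expected, beyond the scatter but without any pointer to how far, since compound 1 itself has no number. For compound 4 the estimated value in this assay is 3000 nM, in the range 300 nM to 20000 nM, corresponding to an expected step of an at least 3.3-fold lower number from compound 1 to compound 4 (0.52 log units; beyond the scatter).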

Compound 4, inhibition constant: 1300 nM
Compound 4: middle estimate off by 2.3-fold (0.36 log units), on the high side; the range from low to high includes it.
By their numbers in this assay, from the lowest: compound 3; then compound 2; then compound 4. At a limit, above all of these: compound 1.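

In this assay, putting 5-methoxypyridin-2-yl in place of pyridin-4-yl gives an at least 7.6-fold lower number from compound 1 to compound 4 (0.88 log units; beyond the scatter). Among these compounds, this is the first step that can be read on the shared core, and it shows that binding responds to which ring sits at this place, on an aromatic carbon para to a large group. The true size of the step stays unknown, since compound 1 has only a limit and not a number: the limit of > 10000 nM in this assay, at which 1 of the 4 values shown sits.

The change alters two things at once, the point at which the pyridine ring is attached and the added methoxy group, so their shares in the gain cannot be told apart. Also open, from the compounds shown here alone, is how binding would respond to a pyridin-2-yl ring with no substituent, or to one carrying a chlorine or an ethoxy group in place of the methoxy.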